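From an Octyl Chain to a Trifluoromethylphenoxy Group

The compounds below may be only part of what the source reports. "The series", "measured", "known", "first", "only" and "open" are said of these compounds alone.

Compound 1 `CCCCCCCCc1ccc(OCC(=O)Cn2nnc(-c3ccc(Cl)cc3)n2)cc1`: > 8
Compound 2 `CCCCCCCCc1ccc(OC(C)C(=O)Cn2nnc(-c3ccccc3)n2)cc1`: > 8
Compound 3 `CCCCCCCCc1ccc(OC(C)C(=O)Cn2nnc(-c3ccc(Cl)cc3)n2)cc1`: > 8

In a physicochemical assay for lipophilicity, read by HPLC, tested at 5 mM (on this read-out higher numbers stand for higher lipophilicity and lower numbers for lower lipophilicity), compound 1 returns only a limit, > 8. Compound 2 likewise returns a limit, > 8. Compound 3 also returns a limit, > 8, so the three measured values sit together (the limit of > 8 in this assay, at which 3 of the 3 values shown sit). The step that the two limits leave unreadable from compound 1 to compound 3 and the step that the two limits leave unreadable from compound 2 to compound 3 therefore cannot be sized. Compound 4 `CC(Oc1ccc(Oc2ccc(C(F)(F)F)cc2)cc1)C(=O)Cn1nnc(-c2ccc(Cl)cc2)n1` differs from compound 3 by 4-(trifluoromethyl)phenoxy in place of octyl on an aromatic carbon. Neither measured step touches this change, and both remain unreadable, so no size can be drawn from them. Compound 4 is estimated at 7.5, within 6.5 to 8.5. The step of a number at least 0.50 log units lower from compound 3 to compound 4 (beyond the scatter) that this estimate implies is expected to move downward from the limit, though a limit may again be all that is reported.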

Compound 4, partition coefficient: 7
Estimate against measurement, compound 4: 0.50 log units above; low and high end bracket the measured number.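

In this assay, within the data shown here, 4-(trifluoromethyl)phenoxy in place of octyl on an aromatic carbon gives a number at least 1.00 log units lower from compound 3 to compound 4 (beyond the scatter), so this position is the first where a change can be sized. Only compound 4 comes off the limit shared by the others: the limit of > 8 in this assay, at which 3 of the 4 values shown sit.

On these data alone, the methyl and chloro steps cannot be read, so their size with 4-(trifluoromethyl)phenoxy in place stays open. Also open, as far as these compounds go, is whether a hexyl chain or an amine on that aromatic carbon would give a readable number rather than a limit.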